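The compounds below may be only part of what the source reports. "The series", "measured", "known", "first", "only" and "open" are said of these compounds alone.

Measured compounds:

Compound 1, `O=c1ccn([C@@H]2O[C@H](COP(=O)(O)OP(=O)(O)O)[C@@H](O)[C@H]2O)c(SCCc2ccccc2)n1`: in an in vitro functional assay on 1321-N1 cells for agonist activity at P2Y purinoceptor 4 (Homo sapiens), read by scintillation proximity assay and inositol phosphate accumulation (a lower number here means that less compound is needed, a higher number that more compound is needed for the effect), compound 1 gives >= 100000 nM, which is a limit of the assay and not a number.
Compound 2, `CSc1nc(=O)ccn1[C@@H]1O[C@H](COP(=O)(O)O)[C@@H](O)[C@H]1O`: compound 2 gives > 100000 nM, again a limit rather than a number.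
Compound 3, `O=c1[nH]c(=S)ccn1[C@@H]1O[C@H](COP(=O)(O)O)[C@@H](O)[C@H]1O`: compound 3 gives > 100000 nM, also a limit.

Compound 1 therefore stands nowhere in particular on a scale of numbers: its value is a limit, and the two other values shown are limits as well, the limit of > 100000 nM in this assay, at which 2 of the 3 values shown sit, and (the limit of >= 100000 nM in this assay, at which 1 of the 3 values shown sits). Nothing measured here separates one compound from another.

Compound 4, `COc1nc(=O)ccn1[C@@H]1O[C@H](COP(=O)(O)OP(=O)(O)O)[C@@H](O)[C@H]1O`, differs from compound 1 in one place: methoxy in place of phenethylsulfanyl on an aromatic carbon. Among the measured compounds shown here, no pair of measured compounds shows this change, so no measured step tells its size. With every value shown sitting at a limit, the step in this assay is expected to be none beyond the scatter, and compound 4 is expected to sit at a limit too, with a number no higher from compound 1 to compound 4 (the limit leaves the size open). Compound 4 is estimated at 100000 nM, in a range from 20000 nM to 400000 nM.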

Compound 4, half-maximal effective concentration: 4490 nM
Compound 4: middle estimate off by 22-fold (1.35 log units), on the high side; measured number below the stated range.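

In this assay, the aromatic carbon between two ring nitrogen atoms proves sensitive to what it carries: methoxy in place of phenethylsulfanyl gives an at least 22-fold lower number from compound 1 to compound 4 (1.34 log units; beyond the scatter). Compound 4 is thereby the only one of the compounds shown to give a number, so a group at this position can decide whether a number is obtained at all. The step is open on one side, as the value of compound 1 is a limit: the limit of >= 100000 nM in this assay, at which 1 of the 4 values shown sits.

The change swaps sulfur for oxygen and removes the six-membered aromatic ring and most of the chain at once, so the compounds shown cannot say which part of it counts. On these data alone, it also remains open how ethoxy, an amine or a longer alkoxy chain at this carbon on the core of compound 4 would read.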